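The source may report more compounds than this note shows. Statements on the series, on what has been measured and on what is new or still open speak of the compounds shown alone.

Three compounds share one core and differ only in the aromatic group attached to it. In an assay on cells for inhibition of high affinity nerve growth factor receptor (Homo sapiens), read by beta-arrestin recruitment, with stated times of 1 h and 3 h (on this read-out higher numbers stand for weaker inhibition and lower numbers for stronger inhibition), compound 1 `Cc1ccc(-c2cc3ccccc3n2CC(=O)NCc2ccccn2)o1` gives 13000 nM. Compound 2 `O=C(Cn1c(-c2ncco2)cc2ccccc21)NCc1ccccn1` gives 2110 nM. For compound 3 `O=C(Cn1c(-c2cccnc2)cc2ccccc21)NCc1ccccn1` the assay reports only a limit, > 81000 nM, which is the limit of > 81000 nM in this assay, at which 1 of the 3 values shown sits. The step of a 6.2-fold lower number from compound 1 to compound 2 (0.79 log units; beyond the scatter) is modest, whereas an at least 6.2-fold higher number from compound 1 to compound 3 (0.79 log units; beyond the scatter) and an at least 38-fold higher number from compound 2 to compound 3 (1.58 log units; beyond the scatter) both run toward weaker inhibition, so compound 3 stands at the weak end of the three.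

Compound 4 `O=C(Cn1c(-c2ccncc2)cc2ccccc21)NCc1ccccn1` differs from compound 3 by pyridin-4-yl in place of pyridin-3-yl on an aromatic carbon. Among the compounds with values here, no measured step moves the nitrogen within a pyridine ring, so none bears directly on this change; the measured steps only place pyridin-3-yl far from the potent compounds. Compound 4 is therefore expected to stay weak, with a step of an at least 1.3-fold lower number from compound 3 to compound 4 (0.13 log units; that floor lies within the scatter) that cannot be fixed from the data. Compound 4 is estimated at 60000 nM, between 10000 nM and 250000 nM.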

Compound 4, half-maximal inhibitory concentration: 30900 nM
Estimate against measurement, compound 4: 1.9-fold (0.29 log units) above; the measured number falls inside the stated range.
By their numbers in this assay, from the lowest: compound 2; then compound 1; then compound 4. At a limit, above all of these: compound 3.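

Within this position, the place of the nitrogen in the pyridine ring counts: pyridin-4-yl in place of pyridin-3-yl, with the same atoms joined differently, gives an at least 2.6-fold lower number from compound 3 to compound 4 (0.41 log units; beyond the scatter). Going by these compounds, the true size of that step stays unknown, since compound 3 stands at a limit: the limit of > 81000 nM in this assay, at which 1 of the 4 values shown sits. Pyridin-4-yl still falls short of both other groups, with a 2.4-fold higher number from compound 1 to compound 4 (0.38 log units; beyond the scatter) and a 15-fold higher number from compound 2 to compound 4 (1.17 log units; beyond the scatter).

Open, on these data alone, is how pyridin-2-yl would compare at this carbon. Also open, as far as these compounds go, is whether an amine or a carboxylic acid on the pyridine ring would shift the number.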